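A few compounds are considered here, and "the series" means these few. Any claim that something is new, unique, unknown or untested is made for them only; others in the source may bear on it.

Compound 1 `C=C1C(=O)O[C@H]2[C@H]1CC/C(Cn1cc(Cn3cc(F)c(=O)[nH]c3=O)nn1)=C\CC[C@@]1(C)O[C@@H]21`: > 20000 nM (a limit)
Compound 2 `C=C1C(=O)O[C@H]2[C@H]1CC/C(COC(=O)Cn1cc(F)c(=O)n(Cc3ccc(Cl)cc3)c1=O)=C\CC[C@@]1(C)O[C@@H]21`: 2560 nM

These values come from a functional assay on Bel-7402 cells (Homo sapiens) for antiproliferative activity, read by MTT assay, with a stated time of 72 h; on this read-out higher numbers stand for weaker inhibition and lower numbers for stronger inhibition. The entry for compound 1 is a limit, not a number. Within the data shown here, that leaves compound 2, at 2560 nM, as the only true number so far.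

Compound 3 `C=C1C(=O)O[C@H]2[C@H]1CC/C(COC(=O)Cn1cc(F)c(=O)n(Cc3ccc(F)cc3F)c1=O)=C\CC[C@@]1(C)O[C@@H]21` differs from compound 2 in one place: 2,4-difluorophenyl in place of 4-chlorophenyl on a saturated chain carbon bound to an aromatic nitrogen. It has 2,4-difluorophenyl in place of 4-chlorophenyl on a saturated chain carbon bound to an aromatic nitrogen. Among the measured compounds shown here, no measured pair shows what this swap does, so no change beyond the scatter is expected. The estimated move is a 1.2-fold higher number from compound 2 to compound 3 (0.07 log units; within the scatter). For compound 3 the expected value is 3000 nM, with an estimated range of 1200 nM to 8000 nM.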

Compound 3, half-maximal inhibitory concentration: 3670 nM
The estimate for compound 3 lay 1.2-fold (0.09 log units) below the measured number; the measured number falls inside the stated range.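

In this assay, the change gives a 1.4-fold higher number from compound 2 to compound 3 (0.16 log units; within the scatter), so on a saturated chain carbon bound to an aromatic nitrogen, 2,4-difluorophenyl and 4-chlorophenyl cannot be told apart. Among these compounds, this is the first readable step at this position, and it shows that, for this pair, the halogens on the ring can be exchanged without a clear change in the number. Compound 1 is the only one held at a limit, not a number: the limit of > 20000 nM in this assay, at which 1 of the 3 values shown sits.

The compounds shown leave open whether this position needs halogens on the ring at all. Plain phenyl, a methoxy-bearing phenyl, a pyridine ring or a longer chain could answer that.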